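The source may report more compounds than this note shows. Statements on the series, on what has been measured and on what is new or still open speak of the compounds shown alone.

In a functional assay on A549 cells (Homo sapiens) for cytotoxicity, with a stated time of 48 h (a higher number here means a weaker inhibitor, a lower number a stronger inhibitor), compound 1 `CCCC(=O)Oc1ccc2oc(/C=C/[S+](C)[O-])cc(=O)c2c1` gives 2200 nM, compound 2 `CC(C)CC(=O)Oc1ccc2oc(/C=C/[S+](C)[O-])cc(=O)c2c1` gives 2300 nM and compound 3 `Cc1cccc2c(=O)cc(/C=C/[S+](C)[O-])oc12` gives 1700 nM. Compound 2 lies within the scatter of both other compounds. Compound 4 `C[S+]([O-])/C=C/c1cc(=O)c2cc(C#N)ccc2o1` carries cyano in place of (isobutylcarbonyl)oxy on an aromatic carbon. Among the measured compounds shown here, the one measured step, a 1.0-fold higher number from compound 1 to compound 2 (0.02 log units; within the scatter), is only a methyl in place of hydrogen on a saturated chain carbon, and it stays within the scatter. It says little about replacing the whole group. Compound 3, which lacks that group, gives 1700 nM, so no shift beyond the scatter is expected. The estimated step is a 1.2-fold lower number from compound 2 to compound 4 (0.06 log units; within the scatter). For compound 4 the expected value is 2000 nM, with an estimated range of 800 nM to 5000 nM.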

Compound 4, half-maximal inhibitory concentration: > 10000 nM
Compound 4: a limit, no number; the forecaster's own chance of this, stated with the estimate: 3%; middle value at least 5.0-fold (0.69 log units) away from the limit.
By their numbers in this assay, from the lowest: compounds 3, 1 and 2 (each within the scatter of the next). At a limit, above all of these: compound 4.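

Compound 4 reads only as a limit in this assay, not as a number: the limit of > 10000 nM in this assay, at which 1 of the 4 values shown sits. On this aromatic carbon the group matters: cyano in place of (isobutylcarbonyl)oxy gives an at least 4.3-fold higher number from compound 2 to compound 4 (0.63 log units; beyond the scatter), and cyano in place of (propylcarbonyl)oxy gives an at least 4.5-fold higher number from compound 1 to compound 4 (0.65 log units; beyond the scatter). The earlier change on the chain stayed within the scatter, so only replacing the whole group reveals a shift. The compounds shown leave open how large these steps really are. They also leave open whether an amine or a carboxylic acid on this carbon would behave like cyano or like the two carbonyloxy groups.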